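Aromatic substituent swap from compound 2 to compound 4

The source may report more compounds than this note shows. Statements on the series, on what has been measured and on what is new or still open speak of the compounds shown alone.

Measured compounds:
compound 1 `CCCCCCCCC(=O)NCc1cc(OC)c(O)cc1Br` — 16.1 nM in an assay on HEK293 cells for inhibition of transient receptor potential cation channel subfamily V member 1 (Homo sapiens); on this read-out higher numbers stand for weaker inhibition and lower numbers for stronger inhibition
compound 2 `CCCCCCCCC(=O)NCc1cc(OC)c(O)cc1Cl` — 50.3 nM
compound 3 `CCCCCCCCC(=O)NCc1cc(Br)c(O)c(OC)c1` — 252 nM

Compound 2 stands second highest of the three numbers: compound 1 sits lower and compound 3 higher, both gaps beyond the scatter. Compound 4 `CCCCCCCCC(=O)NCc1cc(OC)c(O)cc1/C=C/C(=O)OC` carries 2-(methoxycarbonyl)ethenyl in place of chloro on an aromatic carbon. Going by the values given here, the only single-point step on record is a 3.1-fold higher number from compound 1 to compound 2 (0.49 log units; beyond the scatter), a halogen swap at this same carbon; compound 3 differs from compound 2 in substitution pattern, not in one group, so no measured step covers a substituent of this size. The expectation rests mainly on the direction of a 3.1-fold higher number from compound 1 to compound 2 (0.49 log units; beyond the scatter), where the smaller group gave the weaker number, which is taken loosely as the estimate a 1.4-fold lower number from compound 2 to compound 4 (0.16 log units; within the scatter). Compound 4 is therefore expected near 35 nM, within 9 nM to 140 nM, in this assay.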

Compound 4, half-maximal inhibitory concentration: 3930 nM
Compound 4: middle estimate off by 110-fold (2.05 log units), on the low side, and the stated range ends below it.
By their numbers in this assay, from the lowest: compound 1; then compound 2; then compound 3; then compound 4.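

On this aromatic carbon, para to a methoxy group, the halogen order does not carry over to 2-(methoxycarbonyl)ethenyl: in this assay the swap gives a 78-fold higher number from compound 2 to compound 4 (1.89 log units; beyond the scatter) and, against the bromo analogue, a 240-fold higher number from compound 1 to compound 4 (2.39 log units; beyond the scatter). Both steps are large, whereas the halogen swap alone gave only a modest 3.1-fold higher number from compound 1 to compound 2 (0.49 log units; beyond the scatter), so compound 4 goes against the trend seen between compound 1 and compound 2. No supporting measurement accounts for this loss. As far as these compounds go, it remains open whether a carboxylic acid in place of the methyl ester, or a saturated ethylene link in place of the ethenyl, would behave differently at this carbon.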